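Taking the cyano group off compound 3

The source may hold more compounds than are shown below. What is called first, only, known or untested is meant among the compounds shown, and "the series" means these compounds.

Compound 1 `CC1Cn2c(nc([N+](=O)[O-])c2-c2ccc(CO)cc2)O1` gives > 500000 nM as a limit
Compound 2 `Cc1ccc(-c2c([N+](=O)[O-])nc3n2CC(C)O3)cc1` gives > 250000 nM as a limit
Compound 3 `CC1Cn2c(nc([N+](=O)[O-])c2-c2cccc(C#N)c2)O1` gives > 500000 nM as a limit

In an ADME assay on CHO cells (Cricetulus griseus) for cytotoxicity, read by MTT assay, with a stated time of 24 h (on this read-out lower numbers stand for higher toxicity in this test and higher numbers for lower toxicity in this test), compound 3 gives > 500000 nM as a limit and not as a number. Compound 3 and compound 1 sit at the limit of > 500000 nM in this assay, at which 2 of the 3 values shown sit, and no order can be read between them. Compound 2 sits at the limit of > 250000 nM in this assay, at which 1 of the 3 values shown sits, and so none of the three carries a true number.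

Compound 4 `CC1Cn2c(nc([N+](=O)[O-])c2-c2ccccc2)O1` comes from compound 3 by one change hydrogen in place of cyano on an aromatic carbon that is hydrogen in place of cyano on an aromatic carbon. Within the data shown here, the only measured step that the two limits leave unreadable from compound 1 to compound 2 concerns a different group, hydroxy on a saturated chain carbon, and has no readable size. Among the measured compounds shown here, no step for the cyano group has been measured. The expectation therefore rests on compound 3 and its > 500000 nM which is again only a limit. No step beyond the scatter is expected in this assay and the estimated move is a number no higher from compound 3 to compound 4 (the limit leaves the size open) for now. A limit is the likeliest report for compound 4 as well. For compound 4 the expected value is 500000 nM within an estimated range of 200000 nM to 1000000 nM as a working guess.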

Compound 4, half-maximal cytotoxic concentration: > 500000 nM
Compound 4: only a limit was reported (the forecaster's own chance of this, stated with the estimate: 80%); the middle value sits exactly at the limit.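

Compound 4 gives only a limit in this assay, as do compound 1, compound 2 and compound 3, so the steps from each of them to compound 4 cannot be read. The compounds shown leave open where the true half-maximal cytotoxic concentration of each lies.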